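A few compounds are considered here, and "the series" means these few. Any claim that something is new, unique, unknown or untested is made for them only; others in the source may bear on it.

Of the compounds shown here, three have so far been tested in a functional assay on A549 cells (Homo sapiens) for inhibition, read by MTT assay, with a stated time of 48 h; a higher number here means a weaker inhibitor, a lower number a stronger inhibitor. Compound 2 `COc1ccc2c(=O)c(/C=C/C(=O)NCc3cccc(F)c3)coc2c1` gives 26900 nM in this assay. Compound 3 `O=C(/C=C/c1coc2cc(O)ccc2c1=O)Nc1ccccc1` gives 24400 nM in this assay, and this number and that of compound 2 lie within the scatter of each other, so the two cannot be told apart. Compound 1 `COc1ccc(CNC(=O)/C=C/c2coc3cc(O)ccc3c2=O)cc1` reached the limit of > 100000 nM in this assay, at which 1 of the 3 values shown sits, and gave > 100000 nM, which is a limit of this assay rather than a number. Of the two numbers shown, compound 2 stands as the highest, though its gap to compound 3 is within the scatter.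

Compound 4 `COc1ccc2c(=O)c(/C=C/C(=O)NCc3ccc(F)cc3F)coc2c1` has not yet been measured. It differs from compound 2 in one place: 2,4-difluorophenyl in place of 3-fluorophenyl on a saturated chain carbon bound to an amide-type nitrogen. Among the measured compounds shown here, no pair of measured compounds that differ in one place is available here, so these data give no measured step to set the size or direction of such a change. In this assay the expected change is a 1.1-fold lower number from compound 2 to compound 4 (0.03 log units; within the scatter), nothing beyond the scatter. Compound 4 is therefore estimated at 25000 nM, with a likely range from 8000 nM to 80000 nM.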

Compound 4, half-maximal inhibitory concentration: 13300 nM
Compound 4: the middle estimate sits 1.9-fold (0.27 log units) above what was measured, and the stated range covers the measured number.
By their numbers in this assay, from the lowest: compounds 4, 3 and 2 (each within the scatter of the next, the first and the last beyond it). At a limit, above all of these: compound 1.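

Among the compounds shown here, replacing 3-fluorophenyl with 2,4-difluorophenyl on a saturated chain carbon bound to an amide-type nitrogen gives in this assay a 2.0-fold lower number from compound 2 to compound 4 (0.31 log units; beyond the scatter) and so provides the first measured step at this place. The groups that leave and enter differ by one fluorine atom, which shows that a small edit here can move the number, although the step is modest and only just clears the scatter. Nothing measured here bears on why the number moves.

A single step cannot show whether further changes at this place would carry the number lower or reverse it. As far as these compounds go, a plain phenyl, a chlorine atom in place of fluorine, or a longer chain between the amide nitrogen and the ring remains open, as does whether any such change would give more than this modest step.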